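The source may report more compounds than this note shows. Statements on the series, on what has been measured and on what is new or still open speak of the compounds shown alone.

Working notes on a physicochemical assay for solubility, in phosphate buffer, with a stated time of 24 h, at pH 7.4, tested at 100 uM; a lower number here means a less soluble compound, a higher number a more soluble compound. Compound 3 (`CC(=O)N1CCC(S(=O)(=O)c2ccc(CNC(=O)N3Cc4ccncc4C3)cc2)CC1`) gives 187000 nM and compound 1 (`O=C(NCc1ccc(S(=O)(=O)c2ccccc2)cc1)N1Cc2ccncc2C1`) gives 115000 nM, within the scatter of each other, while compound 2 (`O=C(NCc1ccc(S(=O)(=O)c2cc(F)cc(F)c2)cc1)N1Cc2ccncc2C1`) gives 16000 nM. The measured steps are a 7.2-fold lower number from compound 1 to compound 2 (0.86 log units; beyond the scatter), a 12-fold higher number from compound 2 to compound 3 (1.07 log units; beyond the scatter) and a 1.6-fold higher number from compound 1 to compound 3 (0.21 log units; within the scatter). Compound 4 (`O=C(NCc1ccc(S(=O)(=O)N2CCOCC2)cc1)N1Cc2ccncc2C1`) has morpholin-4-yl in place of 1-acetylpiperidin-4-yl on a sulfonyl sulfur. Within the data shown here, no measured step covers this exchange directly. The closest guide is compound 3, whose step a 1.6-fold higher number from compound 1 to compound 3 (0.21 log units; within the scatter) stayed within the scatter, while only the 3,5-difluorophenyl of compound 2 gave a large shift. The expected change is a 1.2-fold lower number from compound 3 to compound 4 (0.10 log units; within the scatter), so no step beyond the scatter is expected. Compound 4 is estimated at 150000 nM, with an expected range of 70000 nM to 300000 nM.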

Compound 4, solubility: 59000 nM
Compound 4: the middle estimate sits 2.5-fold (0.41 log units) above what was measured; the whole stated range lies above it.
By their numbers in this assay, from the lowest: compound 2; then compounds 4, 1 and 3 (each within the scatter of the next, the first and the last beyond it).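

In this assay, the two non-aromatic six-membered rings on the sulfonyl sulfur are not interchangeable: the exchange gives a 3.2-fold lower number from compound 3 to compound 4 (0.50 log units; beyond the scatter), so such a ring alone does not hold the number at the level of compound 3. Morpholin-4-yl also stands clear of the 3,5-difluorophenyl, with a 3.7-fold higher number from compound 2 to compound 4 (0.57 log units; beyond the scatter), while a 1.9-fold lower number from compound 1 to compound 4 (0.29 log units; within the scatter) leaves it level with phenyl. Nothing measured here accounts for these differences. Open, as far as these compounds go, is whether a plain piperidin-4-yl, without the acetyl, would stay with compound 3 or fall toward compound 4. From the compounds shown here alone, a dimethylamino group on the sulfonyl sulfur is equally open.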